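The compounds below may be only part of what the source reports. "The series", "measured", "known", "first", "only" and "open" are said of these compounds alone.

Compound 1, `CCCCOC(=O)NS(=O)(=O)c1ccc(CCC)cc1-c1ccc(Cn2c(CC)nc3ccccc32)cc1`, was tested in an assay on membranes from HEK293 cells for displacement of a labelled ligand from Type-2 angiotensin II receptor (Homo sapiens), read by radioligand binding (on this read-out lower numbers stand for stronger inhibition and higher numbers for weaker inhibition), and gave 11 nM. Compound 2, `CCCCOC(=O)NS(=O)(=O)c1ccc(CCC)cc1-c1cc(F)c(Cn2c(C(C)(C)C)nc3ccccc32)c(F)c1`, carries a different group on the same part of the shared core together with two fluorine atoms, and in this assay compound 2 gives 11 nM. Compound 1 therefore stands level with compound 2 at the digits shown, the two values lying within the scatter of each other, so no order between them can be read from these numbers.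

The next compound, compound 3, is `CCCCOC(=O)NS(=O)(=O)c1ccc(CCC)cc1-c1ccc(Cn2c(C)nc3ccccc32)cc1`. It is not yet measured. Against compound 1 it differs by a single point: hydrogen in place of methyl on a saturated chain carbon bound to an aromatic carbon. Cut one bond further out, the same change reads ethyl to methyl, that is, 2-ethyl-1H-benzimidazol-1-yl to 2-methyl-1H-benzimidazol-1-yl.

Going by the values given here, no measured pair in this set isolates that change, so the size of the step can only be expected, not read. The step of a 1.6-fold higher number from compound 1 to compound 3 (0.21 log units; within the scatter) is expected to be small, within or barely beyond the scatter, with a slight lean toward weaker binding. Compound 3 is therefore estimated at 18 nM, within a range of 6 nM to 55 nM in this assay.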

Compound 3, inhibition constant: 9.4 nM
Beside the measured number, compound 3's estimate is 1.9-fold (0.28 log units) above it, and the stated range covers the measured number.
By their numbers in this assay, from the lowest: compounds 3, 1 and 2 (each within the scatter of the next).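

In this assay, going by these compounds alone, going from 2-ethyl-1H-benzimidazol-1-yl to 2-methyl-1H-benzimidazol-1-yl gives a 1.2-fold lower number from compound 1 to compound 3 (0.07 log units; within the scatter), and this is the first step in the set that isolates a change at a single place. Between these two groups, the loss of one carbon from the saturated chain therefore leaves no readable difference in binding, and the numbers set neither group ahead of the other at this position. Nothing available here bears on why the binding stays within the scatter across this change.

Within the data shown here, compound 2 differs from compound 1 and from compound 3 in more than one place, so no step to it can be read, and the separate contributions of its tert-butyl group and its two fluorine atoms stay unresolved. Ethyl and methyl also cover only a narrow range of groups, so it remains open whether a longer chain such as butyl, or a chain ending in an amine or a carboxylic acid, would leave the number in this assay equally undisturbed.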